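Series notes: piperidinylmethyl to hydrogen on the amine

The compounds below may be only part of what the source reports. "The series", "measured", "known", "first", "only" and "open" are said of these compounds alone.

Measured compounds:
compound 1 `N#CC1=C(NCN2CCCCC2)N(c2ccccc2)C(=O)N2CCCCC(N3CCCC3)C12` — 36.9%
compound 2 `N#Cc1c2n(c(=O)n(-c3ccccc3)c1=N)CCCCC2N1CCCC1` — 88.7%

In a functional assay on the whole organism (strain albino) for inhibition, with Rattus norvegicus as the target, read by paw edema, with stated times of 1 h and 2 h, at a dose of 20 mmol/kg by the intraperitoneal route (a higher number here means more inhibition at the dose given (going by the name of the read-out), a lower number less inhibition), compound 1 gives 36.9%. In the same read-out compound 2 gives 88.7%. Within the data shown here, of the two numbers compound 1 stands lowest, and the gap to compound 2 lies beyond the scatter; no single-point step between the two measured compounds is defined, so their values are only set side by side.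

Compound 3 `N#CC1=C(N)N(c2ccccc2)C(=O)N2CCCCC(N3CCCC3)C12` differs from compound 1 in one place: hydrogen in place of (piperidin-1-yl)methyl on an amine nitrogen. Neither measured compound shows the effect of this change, so the expectation rests on compound 1 alone and carries wide uncertainty. A step from compound 1 to compound 3 of a number 13.1 percentage points higher from compound 1 to compound 3 (beyond the scatter) is expected, upward but of modest size and possibly within the scatter. Compound 3 is accordingly estimated at 50%, with a range from 25% to 75%.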

Compound 3, a percentage reported as inhibition, in the whole organism at one dose (the size of the read-out at that dose, not a potency): 86.9%
Estimate against measurement, compound 3: 36.9 percentage points below, outside the stated range (above it).
By their numbers in this assay, from the lowest: compound 1; then compounds 3 and 2 (each within the scatter of the next).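

In this assay, among these compounds, hydrogen in place of (piperidin-1-yl)methyl on the amine nitrogen gives a number 50 percentage points higher from compound 1 to compound 3 (beyond the scatter), so the substituent on this nitrogen bears strongly on the read-out, which no earlier pair could show. Of these two forms, the amino form of compound 3 gives the higher inhibition at the dose tested, and the ((piperidin-1-yl)methyl)amino form of compound 1 the lower. No measurement at hand accounts for the size of this step.

Going by these compounds, it remains open whether the lower value of compound 1 goes with the piperidine ring or with any substituent on this nitrogen; a methyl group or a morpholin-4-ylmethyl group in the same place would separate the two. On these data alone, whether the step holds with a different amine in place of the pyrrolidine on the shared core also remains open.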